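Iodo in place of fluoro: an expected cytotoxicity reading

The source may hold more compounds than are shown below. What is called first, only, known or untested is meant among the compounds shown, and "the series" means these compounds.

Compound 3 `Oc1cc(C(F)(F)F)ccc1-c1nc(-c2ccccc2O)n(-c2ccc(F)cc2)n1` gives 86.7% in a functional assay on PC-12 cells (Rattus norvegicus) for cytotoxicity, read by MTT assay, with stated times of 2 h and 24 h, tested at 5 uM (a higher number here means a stronger effect of the compound at the concentration tested, a lower number a weaker effect), the second highest of three numbers. Compound 1 `Cc1ccc(-n2nc(-c3ccc(C(F)(F)F)cc3O)nc2-c2ccccc2O)cc1` gives 94.1% and compound 2 `CC(C)(C)c1ccc(-n2nc(-c3ccc(C(F)(F)F)cc3O)nc2-c2ccccc2O)cc1` gives 77.8%; the step of a number 7.4 percentage points lower from compound 1 to compound 3 (within the scatter) and the step of a number 8.9 percentage points higher from compound 2 to compound 3 (within the scatter) both lie within the scatter. Compound 4 `Oc1cc(C(F)(F)F)ccc1-c1nc(-c2ccccc2O)n(-c2ccc(I)cc2)n1` differs from compound 3 by iodo in place of fluoro on an aromatic carbon. Going by the values given here, no measured step exchanges one halogen for another; the nearest guide is a number 16.3 percentage points lower from compound 1 to compound 2 (beyond the scatter), where the larger group went with the lower number, while the two steps into compound 3 showed no change beyond the scatter. Compound 4 is therefore expected to give 80% (64% to 94%), a step of a number 6.7 percentage points lower from compound 3 to compound 4 (within the scatter) that may just reach beyond the scatter.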

Compound 4, a percentage reported as activity, at one concentration (the size of the read-out at that concentration, not a potency): 94.4%
Compound 4: the middle estimate sits 14.4 percentage points below what was measured, outside the stated range (above it).
By their numbers in this assay, from the lowest: compounds 2, 3, 1 and 4 (each within the scatter of the next, the first and the last beyond it).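

At this position, on an aromatic carbon para to a large group, the change from 4-fluorophenyl to 4-iodophenyl is the first halogen exchange shown, and in this assay it stays within the scatter (a number 7.7 percentage points higher from compound 3 to compound 4 (within the scatter)). Iodo and methyl also read alike (a number 0.3 percentage points higher from compound 1 to compound 4 (within the scatter)), whereas iodo in place of tert-butyl does not (a number 16.6 percentage points higher from compound 2 to compound 4 (beyond the scatter)), so the tert-butyl compound is set apart from the methyl and iodo compounds but not from the fluoro compound. No evidence on the cause of these readings is available. Still open, on these data alone, is how an amine or a carboxylic acid at this position would read.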